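Swapping the aromatic substituent on a shared coumarin-free core

This account rests on a few compounds, and the source may have more. Where it says the series, first, only, none or still open, it means among the compounds named here.

The series rests on a shared core in which the substituent on one aromatic carbon is varied, measured in an assay on isolated protein (strain Sprague-Dawley) for inhibition of Amine oxidase [flavin-containing] B (Rattus norvegicus), read by spectrophotometry, with a stated time of 5 min; on this read-out higher numbers stand for weaker inhibition and lower numbers for stronger inhibition. Compound 1 `O=c1cc(Oc2ccccc2)c2ccc(OCc3cccc(Cl)c3)cc2o1` carries a phenoxy group there and gives 4070 nM. Compound 2 `CNc1cc(=O)oc2cc(OCc3cccc(Cl)c3)ccc12` carries a methylamino group and gives 8.71 nM, the lowest of the two numbers; the one change shown, a 470-fold lower number from compound 1 to compound 2 (2.67 log units; beyond the scatter), is a large step, so this position clearly matters. Compound 3 `CCOC(=O)c1cc(=O)oc2cc(OCc3cccc(Cl)c3)ccc12` introduces the change (ethoxycarbonyl in place of methylamino on an aromatic carbon). Going by the values given here, only the step from compound 1 to compound 2 bears on it, and it shows the position is sensitive but gives no sign for a group that is neither phenoxy nor methylamino. The estimate for compound 3 is therefore a moderate rise, a 5.7-fold higher number from compound 2 to compound 3 (0.76 log units; beyond the scatter), giving an expected 50 nM with a range from 5 nM to 500 nM.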

Compound 3, half-maximal inhibitory concentration: 417 nM
Beside the measured number, compound 3's estimate is 8.3-fold (0.92 log units) below it; the measured number falls inside the stated range.
By their numbers in this assay, from the lowest: compound 2; then compound 3; then compound 1.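

The change to ethoxycarbonyl shows that this position does not simply reward any departure from phenoxy: in this assay there is a 48-fold higher number from compound 2 to compound 3 (1.68 log units; beyond the scatter) and also a 9.8-fold lower number from compound 1 to compound 3 (0.99 log units; beyond the scatter) and so the three groups fall on three separate levels. Methylamino stays lowest of the three, and the low number of compound 2 is not shared by ethoxycarbonyl, the other group here without a ring. Nothing measured here gives a reason for these steps.

The compounds shown leave open whether the low number follows the nitrogen of methylamino, with only one amine among them. A plain amino group, a dimethylamino group, an ethylamino chain or a free carboxylic acid on the same aromatic carbon would each test a separate part of that question.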